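Replacing dimethylamino with a pyrazolyl ring on the shared core

The source may report more compounds than this note shows. Statements on the series, on what has been measured and on what is new or still open speak of the compounds shown alone.

The measured compounds and their values:
Compound 1, `CNc1nc(NC)nc(NC2(C#N)CCCCC2)n1`, gives 210 mL/min/kg in an ADME assay on microsomes from liver (Rattus norvegicus) for metabolic stability; a higher number here means faster removal of the compound, a lower number slower removal.
Compound 2, `CNc1nc(C#N)nc(NC2(C#N)CCCCC2)n1`, gives 122 mL/min/kg in this assay.
Compound 3, `CNc1nc(NC2(C#N)CCCCC2)nc(N(C)C)n1`, gives 276 mL/min/kg in this assay.

Compound 3 stands highest of the three numbers in this assay. Its nearest neighbour is compound 1, with a 1.3-fold higher number from compound 1 to compound 3 (0.12 log units; within the scatter), a difference within the scatter, so no order can be claimed between the two. The step of a 2.3-fold higher number from compound 2 to compound 3 (0.35 log units; beyond the scatter) is the only one beyond the scatter, and the step of a 1.7-fold lower number from compound 1 to compound 2 (0.24 log units; within the scatter) lies within it.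

Compound 4, `CNc1nc(NC2(C#N)CCCCC2)nc(-n2cccn2)n1`, differs from compound 3 at a single point: 1H-pyrazol-1-yl in place of dimethylamino on an aromatic carbon. The step from compound 2 to compound 3 shows that exchanging the group on this carbon can shift this assay by a modest amount, while the step from compound 1 to compound 3 shows that a small change on the same group stays within the scatter. Going by the values given here, no measured step exchanges dimethylamino for an aromatic ring, so the direction is open; a change of about the size seen between compound 2 and compound 3, in either direction, is the most that the data support.

Compound 4 is therefore expected to sit near compound 3, with the estimated step of a 1.2-fold lower number from compound 3 to compound 4 (0.08 log units; within the scatter). The estimate for compound 4 in this assay is 230 mL/min/kg, expected to fall between 110 mL/min/kg and 480 mL/min/kg.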

Compound 4, clearance: 103 mL/min/kg
Estimate against measurement, compound 4: 2.2-fold (0.35 log units) above, outside the stated range (below it).
By their numbers in this assay, from the lowest: compounds 4, 2, 1 and 3 (each within the scatter of the next, the first and the last beyond it).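

In this assay, going by these compounds alone, this carbon now carries an aromatic ring for the first time, and the exchange of dimethylamino for 1H-pyrazol-1-yl gives a 2.7-fold lower number from compound 3 to compound 4 (0.43 log units; beyond the scatter). The exchange of methylamino for the same ring gives a 2.0-fold lower number from compound 1 to compound 4 (0.31 log units; beyond the scatter), so the ring stands apart from both amino groups by more than the scatter. Against cyano, the ring gives a 1.2-fold lower number from compound 2 to compound 4 (0.07 log units; within the scatter), so no order can be claimed between these two, and the data offer nothing that would explain any of these steps.

On these data alone, it stays open whether these lower numbers belong to 1H-pyrazol-1-yl alone or extend to other rings on this carbon, such as imidazol-1-yl or phenyl. As far as these compounds go, how a small ether such as methoxy would compare at this position also remains open.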